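Phenyl for Pyridin-2-yl on the Amine Nitrogen

A few compounds are considered here, and "the series" means these few. Any claim that something is new, unique, unknown or untested is made for them only; others in the source may bear on it.

Of the compounds shown here, three sharing one core have been tested in a functional assay on the whole organism (strain Wistar) for inhibition, with Rattus norvegicus as the target, read by paw edema, with a stated time of 3 h, at a dose of 100 umol/kg by the oral route; on this read-out lower numbers stand for less inhibition and higher numbers for more inhibition at the one dose given (going by the name of the read-out). Compound 1 `c1ccc(Nc2c(-c3ccccc3)nc3ccccn23)cc1` gives 63.9%. Compound 3 `c1ccc(Nc2c(-c3ccccn3)nc3ccccn23)cc1` gives 33.4%, and the step of a number 30.5 percentage points lower from compound 1 to compound 3 (beyond the scatter) shows that pyridin-2-yl in place of phenyl on an aromatic carbon cut the effect sharply. Compound 2 `CS(=O)(=O)c1ccc(-c2nc3ccccn3c2Nc2ccccn2)cc1` gives 17.2%, the lowest of the three, a number beyond the scatter below compound 3 and further still below compound 1.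

Compound 4 `CS(=O)(=O)c1ccc(-c2nc3ccccn3c2Nc2ccccc2)cc1` differs from compound 2 in one place: phenyl in place of pyridin-2-yl on a nitrogen on an aromatic ring. Among the measured compounds shown here, no measured step covers this exact exchange. For the measured compounds named here, the only related step, the move from phenyl to pyridin-2-yl on the aromatic carbon, was large and downward; the reverse direction on the nitrogen is taken as a loose guide, with the caveat that the place differs and the partner group on the aromatic carbon is not the same. Compound 4 is therefore expected to show a number 14.8 percentage points higher from compound 2 to compound 4 (beyond the scatter), a gain though not a confident one. The estimate for compound 4 is 32%, within 12% to 52%.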

Compound 4, a percentage reported as inhibition, in the whole organism at one dose (the size of the read-out at that dose, not a potency): 28.2%
Compound 4: the middle estimate sits 3.8 percentage points above what was measured; the measured number falls inside the stated range.
By their numbers in this assay, from the lowest: compound 2; then compounds 4 and 3 (each within the scatter of the next); then compound 1.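

In this assay, the exchange of pyridin-2-yl for phenyl on a nitrogen on an aromatic ring gives a number 11 percentage points higher from compound 2 to compound 4 (beyond the scatter), so this position responds to the change, though only modestly, and the anilino compound keeps the higher number when methylsulfonyl is present. Methylsulfonyl in place of hydrogen on an aromatic carbon, a change the earlier compounds could not isolate, gives a number 35.7 percentage points lower from compound 1 to compound 4 (beyond the scatter), and this large loss leaves compound 4 far short of the unsubstituted parent. Nothing available explains the size or direction of either step.

The compounds shown leave open whether the gain from phenyl on the nitrogen would also appear without methylsulfonyl. They also leave open how a sulfonamide in place of methylsulfonyl, or a cyclohexyl group in place of phenyl on the nitrogen, would read out.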